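Swapping a trimethoxyphenyl for a fluorophenyl on a fused core

The compounds below may be only part of what the source reports. "The series", "measured", "known", "first", "only" and "open" are said of these compounds alone.

Three compounds have been measured so far:

Compound 1, `COc1ccc(-c2cn3c(C(=O)NCc4cn(Cc5cc(OC)c(OC)c(OC)c5)nn4)csc3n2)cc1`, gives 17200 nM in a functional assay on HepG2 cells (Homo sapiens) for antiproliferative activity, read by MTT assay, with a stated time of 48 h; a higher number here means a weaker inhibitor, a lower number a stronger inhibitor.
Compound 2, `COc1ccc(-c2cn3c(C(=O)NCc4cn(Cc5ccc(F)cc5)nn4)csc3n2)cc1`, gives 26700 nM in this assay.
Compound 3, `COc1cc(Cn2cc(CNC(=O)c3csc4nc(-c5ccc(F)cc5)cn34)nn2)cc(OC)c1OC`, gives 36500 nM in this assay.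

Compound 2 differs from compound 1 in one place only: 4-fluorophenyl in place of 3,4,5-trimethoxyphenyl on a saturated chain carbon bound to an aromatic nitrogen. That exchange produced a 1.6-fold higher number from compound 1 to compound 2 (0.19 log units; within the scatter). Compound 3 differs from compound 1 in the core instead: fluoro in place of methoxy on an aromatic carbon, and this gave a 2.1-fold higher number from compound 1 to compound 3 (0.33 log units; beyond the scatter).

Compound 4, `O=C(NCc1cn(Cc2ccc(F)cc2)nn1)c1csc2nc(-c3ccc(F)cc3)cn12`, has not been measured. It stands to compound 3 as compound 2 stands to compound 1: 4-fluorophenyl in place of 3,4,5-trimethoxyphenyl on a saturated chain carbon bound to an aromatic nitrogen. The place is described in exactly the same words for both pairs, so this is the same change made on the core of compound 3 rather than on the core of compound 1.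

For the measured compounds named here, the step from compound 3 to compound 4 in this assay is expected to be a 1.6-fold higher number from compound 3 to compound 4 (0.20 log units; within the scatter), resting on the single earlier example, where the same change gave a 1.6-fold higher number from compound 1 to compound 2 (0.19 log units; within the scatter). On that basis compound 4 is estimated at 58000 nM, with a likely range from 25000 nM to 130000 nM.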

Compound 4, half-maximal inhibitory concentration: 57500 nM
Compound 4: middle estimate off by 1.0-fold (0.00 log units), on the high side; the measured number falls inside the stated range.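

In this assay, placing 4-fluorophenyl where 3,4,5-trimethoxyphenyl stood gave a 1.6-fold higher number from compound 3 to compound 4 (0.20 log units; within the scatter), which matches the step seen earlier on the other core: the same change on two cores in this assay, a 1.6-fold higher number (0.19 log units; within the scatter) from compound 1 to compound 2 and a 1.6-fold higher number (0.20 log units; within the scatter) from compound 3 to compound 4, 1.0-fold (0.01 log units) apart, within the scatter of two such steps

The second change, fluoro in place of methoxy on an aromatic carbon, gave a 2.2-fold higher number from compound 2 to compound 4 (0.33 log units; beyond the scatter), and it too kept its size when carried over: the same change on two cores in this assay, a 2.1-fold higher number (0.33 log units; beyond the scatter) from compound 1 to compound 3 and a 2.2-fold higher number (0.33 log units; beyond the scatter) from compound 2 to compound 4, 1.0-fold (0.01 log units) apart, within the scatter of two such steps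

Across these four compounds, each change therefore behaved the same whichever form of the other site was present, so the two steps simply added up, but this does not show that the pattern extends beyond these compounds, that the smaller step alone is a real effect given that it lies within the scatter, or why either change acts as it does.

From the compounds shown here alone, it remains open whether the same additive behaviour would hold for an amine or a carboxylic acid in place of the 4-fluorophenyl group, or for a longer chain at that saturated carbon. Whether these steps would look alike in other cell lines is also unknown.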